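The source may hold more compounds than are shown below. What is called first, only, known or untested is meant among the compounds shown, and "the series" means these compounds.

Measured in a functional assay on Huh-7 cells (Homo sapiens) for cytotoxicity, read by MTT assay, with a stated time of 3 days (a lower number here means that less compound is tolerated, a higher number that more compound is tolerated), with every value a limit of the assay and not a number:

Compound 1 (`OC[C@H]1O[C@@H](n2cnc3c(Cn4ccc5ccccc54)ncnc32)[C@H](O)[C@@H]1O`): > 250000 nM
Compound 2 (`O=c1ccn(Cc2ncnc3c2ncn3[C@@H]2O[C@H](CO)[C@@H](O)[C@H]2O)cc1`): > 100000 nM
Compound 3 (`CC(=O)N(Cc1ccccc1)Cc1ncnc2c1ncn2[C@@H]1O[C@H](CO)[C@@H](O)[C@H]1O`): > 100000 nM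

Compound 2 has only a limit here and stands at the limit of > 100000 nM in this assay, at which 2 of the 3 values shown sit, a position it shares with compound 3. Compound 1 stands alone at the limit of > 250000 nM in this assay, at which 1 of the 3 values shown sits, and so is not directly comparable.

Compound 4 (`O=C(O)CNCc1ncnc2c1ncn2[C@@H]1O[C@H](CO)[C@@H](O)[C@H]1O`) departs from compound 2 in one place: a group of 5 heavy atoms (2 carbon, 1 nitrogen, 2 oxygen; no ring) in place of a group of 7 heavy atoms (5 carbon, 1 nitrogen, 1 oxygen; one six-membered aromatic ring with 1 hetero atom), on a saturated chain carbon bound to an aromatic carbon. The (carboxymethyl)amino group thus takes over on the saturated chain carbon bound to an aromatic carbon.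

Among the compounds with values here, the one measured step at that place is a step that the two limits leave unreadable from compound 1 to compound 2, so it offers no size to carry over. Compounds 1, 2 and 3 carry different groups there, yet none gives more than a limit. No step beyond the scatter can therefore be supported, and none is expected in this assay. The expected step is a step that the limit leaves unreadable from compound 2 to compound 4 and will most likely be reported only as a limit. For compound 4 the estimate is 150000 nM, with an expected range from 70000 nM to 300000 nM.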

Compound 4, half-maximal cytotoxic concentration: > 100000 nM
Compound 4: only a limit was reported (the forecaster's own chance of this, stated with the estimate: 85%); the middle value does not contradict the limit.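

In this assay compound 4 gives > 100000 nM, which is a limit of the assay and not a number. Its steps from compound 1 and from compound 2 cannot be read. The compounds shown leave open where the half-maximal cytotoxic concentration of any of them actually lies.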